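From 3-Chlorophenyl to 3,4-Dimethoxyphenyl on the Shared Core

This account rests on a few compounds, and the source may have more. Where it says the series, first, only, none or still open, it means among the compounds named here.

In a functional assay on A2780 cells (Homo sapiens) for antiproliferative activity, read by MTT assay, with a stated time of 48 h (a lower number here means a stronger inhibitor of growth, a higher number a weaker inhibitor of growth), compound 1 (`COC(=O)N1N=C(c2ccccc2)CC1c1cc(OC)c(OC)c(OC)c1`) gives 2770 nM, compound 2 (`COC(=O)N1N=C(c2cccc(C)c2)CC1c1cc(OC)c(OC)c(OC)c1`) gives 600 nM, and compound 3 (`COC(=O)N1N=C(c2cccc(Cl)c2)CC1c1cc(OC)c(OC)c(OC)c1`) gives 1540 nM. Compound 3 thus lies within the scatter of compound 1, with a 1.8-fold lower number from compound 1 to compound 3 (0.25 log units; within the scatter), but is separated from compound 2, with a 2.6-fold higher number from compound 2 to compound 3 (0.41 log units; beyond the scatter). Compound 4 (`COC(=O)N1N=C(c2ccc(OC)c(OC)c2)CC1c1cc(OC)c(OC)c(OC)c1`) has 3,4-dimethoxyphenyl in place of 3-chlorophenyl on a carbon with a double bond to nitrogen. Going by the values given here, the largest related change, a 4.6-fold lower number from compound 1 to compound 2 (0.66 log units; beyond the scatter), is modest, and no measured compound carries a methoxy group on this aryl ring. No shift beyond the scatter is therefore expected in this assay, and no direction is favoured. The expected change is a 1.0-fold lower number from compound 3 to compound 4 (0.01 log units; within the scatter). Compound 4 is estimated at 1500 nM, within an expected range of 450 nM to 5000 nM.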

Compound 4, concentration for 50% growth inhibition: 11400 nM
For compound 4 the middle estimate is 7.6-fold (0.88 log units) below the measured one; measured number outside the range, above it.
By their numbers in this assay, from the lowest: compound 2; then compounds 3 and 1 (each within the scatter of the next); then compound 4.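

In this assay, 3,4-dimethoxyphenyl is the only aryl group shown at this position that gives a higher number than phenyl, a 4.1-fold higher number from compound 1 to compound 4 (0.61 log units; beyond the scatter), and it also separates from 3-chlorophenyl, a 7.4-fold higher number from compound 3 to compound 4 (0.87 log units; beyond the scatter). With the step from 3-methylphenyl, a 19-fold higher number from compound 2 to compound 4 (1.28 log units; beyond the scatter), the position now shows changes in both directions from phenyl, with compound 2 on the lower side and compound 4 on the higher. No supporting data bear on why this shift occurs. The compounds shown leave open whether a single methoxy group on this aryl ring would give the same shift. As far as these compounds go, how an amine there would read also remains open.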